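The source may hold more compounds than are shown below. What is called first, only, known or untested is meant among the compounds shown, and "the series" means these compounds.

Measured so far in a functional assay on HCT-116 cells (Homo sapiens) for antiproliferative activity, read by MTT assay, with a stated time of 48 h; a lower number here means a stronger inhibitor, a higher number a weaker inhibitor:

compound 1 `COc1cccc(C(=O)Nc2cc(Sc3ncn[nH]3)c(O)c3ccccc23)c1`: > 100000 nM, a limit of the assay
compound 2 `COc1ccc(C(=O)Nc2cc(Sc3ncn[nH]3)c(O)c3ccccc23)cc1`: > 100000 nM, a limit of the assay

Compound 2 stands at a limit in this assay. Its reading > 100000 nM is not a number but the point at which the assay stops reporting. Compound 1 gives the same kind of reading, a limit, in this assay. Within the data shown here, the one measured step, a step that the two limits leave unreadable from compound 1 to compound 2, is therefore unreadable in size and direction. Both readings rest on (the limit of > 100000 nM in this assay, at which 2 of the 2 values shown sit).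

Compound 3 `O=C(Nc1cc(Sc2ncn[nH]2)c(O)c2ccccc12)c1ccc2ccccc2c1` differs from compound 2 by naphthalen-2-yl in place of 4-methoxyphenyl on a carbonyl carbon. Among the measured compounds shown here, no measured step bears on a naphthalen-2-yl group, and no step in this assay has yet been read at all, so the expectation for compound 3 rests on the standing of compound 2 alone. Compound 3 is expected to sit at or near the same limit, because compound 2 sits at the limit of > 100000 nM in this assay, at which 2 of the 2 values shown sit. The step from compound 2 to compound 3 is estimated as a number no higher from compound 2 to compound 3 (the limit leaves the size open), nothing beyond the scatter. The estimate for compound 3 in this assay is 100000 nM, within the range 20000 nM to 300000 nM, with a limit reading the most likely outcome.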

Compound 3, half-maximal inhibitory concentration: > 100000 nM
Compound 3: no number, only a limit (the forecaster's own chance of this, stated with the estimate: 70%); the middle value sits exactly at the limit.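

In this assay compound 3 gives > 100000 nM, a limit of the assay and not a number. No new step can be read among compound 1, compound 2 and compound 3, because all three readings stand at the same limit: the limit of > 100000 nM in this assay, at which 3 of the 3 values shown sit.

The compounds shown leave open how 3-methoxyphenyl, 4-methoxyphenyl and naphthalen-2-yl on the carbonyl carbon rank against one another in this assay.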